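A few compounds are considered here, and "the series" means these few. Any claim that something is new, unique, unknown or untested is made for them only; others in the source may bear on it.

Measured in a functional assay on HeLa cells (Homo sapiens) for antiproliferative activity, read by MTT assay, with a stated time of 72 h; a lower number here means a stronger inhibitor, a higher number a weaker inhibitor:
- compound 1 `COc1ccc(-c2ncnn2-c2cc(OC)c(OC)c(OC)c2)cc1`: 280 nM
- compound 2 `COc1cc(-c2ncnn2-c2ccc(N)cc2)cc(OC)c1OC`: > 10000 nM

Among the measured compounds shown here, compound 1 gives 280 nM, the only actual number so far. Compound 2 gives > 10000 nM, which is a limit of the assay and not a number. Compound 3 `COc1cc(-n2ncnc2-c2ccccc2)cc(OC)c1OC` has yet to be measured in this assay. It differs from compound 1 by hydrogen in place of methoxy on an aromatic carbon, para to a large group, so that 4-methoxyphenyl becomes phenyl (hydrogen in place of methoxy on an aromatic carbon). For the measured compounds named here, no measured pair shows what this change does, so the expectation rests on compound 1 alone and is uncertain. A weaker value is expected, with a change beyond the usual scatter. The estimated step is an 11-fold higher number from compound 1 to compound 3 (1.03 log units; beyond the scatter). Compound 3 is expected at about 3000 nM, within an estimated range of 600 nM to 10000 nM.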

Compound 3, half-maximal inhibitory concentration: > 10000 nM
Compound 3 was reported as a limit (the forecaster's own chance of this, stated with the estimate: 30%); middle value at least 3.3-fold (0.52 log units) from the limit.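

In this assay, among the compounds shown here, hydrogen in place of methoxy gives an at least 35-fold higher number from compound 1 to compound 3 (1.55 log units; beyond the scatter), the first comparison here in which only one place differs. It shows that the activity of compound 1 depends on this methoxy group on an aromatic carbon, para to a large group: once 4-methoxyphenyl becomes phenyl, no inhibition is read within the range of the assay. The value of compound 3 is a limit of the assay and not a number, so the step gives only a lower bound on the change: the limit of > 10000 nM in this assay, at which 2 of the 3 values shown sit.

The compounds shown leave open whether the oxygen or the methyl carbon of the methoxy group matters, which a hydroxyl or an ethoxy group on that carbon could address. They also leave open how a chlorine atom or a methyl group there would read in this assay.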